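The source may report more compounds than this note shows. Statements on the series, on what has been measured and on what is new or still open speak of the compounds shown alone.

Compound 1 `COc1cc2ncnc(-n3nc(-c4ccccn4)nc3N)c2cc1N` and compound 2 `COc1cc2ncnc(-n3nc(-c4ccccn4)nc3N)c2cc1OCCCNC(=O)OC(C)(C)C` share one core and differ only at one aromatic carbon. In an assay on MCF7 cells for inhibition of Serine-protein kinase ATM (Homo sapiens), read by immunofluorescence, with a stated time of 1 h (a higher number here means a weaker inhibitor, a lower number a stronger inhibitor), compound 1 gives only a limit, > 40000 nM (the limit of > 40000 nM in this assay, at which 1 of the 2 values shown sits). Compound 2 gives 900 nM in this assay, the only plain number shown, so the step of an at least 44-fold lower number from compound 1 to compound 2 (1.64 log units; beyond the scatter) is large. Compound 3 `COc1cc2ncnc(-n3nc(-c4ccccn4)nc3N)c2cc1OCCCNC(=O)OC(C)C` differs from compound 2 by hydrogen in place of methyl on a saturated chain carbon bound to an oxygen next to a carbonyl group and two saturated chain carbons. Among the compounds with values here, the single measured step changes a different place, so no measured step bears directly on this change, and a step within the scatter is expected, a 1.3-fold higher number from compound 2 to compound 3 (0.12 log units; within the scatter). Compound 3 is therefore estimated at 1200 nM, between 400 nM and 4000 nM.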

Compound 3, half-maximal inhibitory concentration: 1000 nM
The estimate for compound 3 lay 1.2-fold (0.08 log units) above the measured number; measured number inside the range.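

Replacing tert-butyl with isopropyl changes the reading in this assay only within the scatter, a 1.1-fold higher number from compound 2 to compound 3 (0.05 log units; within the scatter), so the loss of this one methyl does not separate the two compounds. The large step also holds with the smaller end group in place: 3-((isopropoxycarbonyl)amino)propoxy in place of amino gives an at least 40-fold lower number from compound 1 to compound 3 (1.60 log units; beyond the scatter). The size of that step rests on a limit rather than a plain number: the limit of > 40000 nM in this assay, at which 1 of the 3 values shown sits.

Still open, going by these compounds, is how much of the isopropoxycarbonyl group is needed. A free amine or a carboxylic acid at the end of the propoxy chain, or a longer chain, could read differently.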